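Aryl substituent swap in the shared core

The source may report more compounds than this note shows. Statements on the series, on what has been measured and on what is new or still open speak of the compounds shown alone.

Measured so far:
compound 1, `CC(C)(C)OC(=O)/C=C1/C(=O)Nc2ccccc21` — 2450 nM
compound 2, `CCCCc1ccc2c(c1)/C(=C\C(=O)OC(C)(C)C)C(=O)N2` — 6190 nM

In a functional assay on HL-60 cells (Homo sapiens) for cytotoxicity, read by CCK-8 assay, with a stated time of 72 h (a higher number here means a weaker inhibitor, a lower number a stronger inhibitor), compound 1 gives 2450 nM and compound 2 gives 6190 nM. Among the measured compounds shown here, compound 2 carries the highest number of the two; its nearest neighbour is compound 1, and the single step joining them, a 2.5-fold higher number from compound 1 to compound 2 (0.40 log units; beyond the scatter), lies beyond the scatter but stays modest in size.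

Compound 3, `CC(C)(C)OC(=O)/C=C1/C(=O)Nc2ccc(OC(F)(F)F)cc21`, differs from compound 2 by trifluoromethoxy in place of butyl on an aromatic carbon. For the measured compounds named here, only one measured step touches this position: the butyl entry from compound 1 to compound 2, which raised the number. Going by the values given here, the new step removes that butyl again, so part of it is the reverse of the measured one, while the trifluoromethoxy that enters has no precedent anywhere. The expected size of the step is therefore set by the measured one: a modest move back toward the number of compound 1, with a wide band to cover the unknown group.

The estimate for compound 3 in this assay is 3500 nM, with a range of 1200 nM to 10000 nM. The expected step from compound 2 is a 1.8-fold lower number from compound 2 to compound 3 (0.25 log units; within the scatter).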

Compound 3, half-maximal inhibitory concentration: 4480 nM
Estimate against measurement, compound 3: 1.3-fold (0.11 log units) below; the range from low to high includes it.
By their numbers in this assay, from the lowest: compounds 1, 3 and 2 (each within the scatter of the next, the first and the last beyond it).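

In this assay trifluoromethoxy in place of butyl gives a 1.4-fold lower number from compound 2 to compound 3 (0.14 log units; within the scatter) and trifluoromethoxy in place of hydrogen gives a 1.8-fold higher number from compound 1 to compound 3 (0.26 log units; within the scatter) on the same aromatic carbon, so compound 3 cannot be separated from either neighbour. Compound 1 and compound 2 remain apart by a 2.5-fold higher number from compound 1 to compound 2 (0.40 log units; beyond the scatter) while compound 3 lies within the scatter of both, which shows that this aromatic carbon can carry a second group, with atoms quite unlike those of butyl, without a step beyond the scatter from either compound. No measurement is available that would explain these small steps, and the numbers alone describe the position only as a cell read-out.

The compounds shown leave open how an amine or a carboxylic acid on this aromatic carbon would read, and whether a longer chain such as hexyl would take the number further from that of compound 1 than butyl does. They also leave open whether the other aromatic carbons of the shared core respond as this one does, and whether any group at this place can give a lower number than compound 1.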